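The compounds below may be only part of what the source reports. "The series", "measured", "known", "first", "only" and "open" are said of these compounds alone.

Measured so far:
compound 1, `CCCCOC(=O)OCC1OC(n2cc(C)c(=O)[nH]c2=O)CC1N=[N+]=[N-]`: 1.02
compound 2, `Cc1cn(C2CC(N=[N+]=[N-])C(COC(=O)NCCCC(=O)O)O2)c(=O)[nH]c1=O`: -0.81
compound 3, `Cc1cn(C2CC(N=[N+]=[N-])C(COC(=O)OCCCCCO)O2)c(=O)[nH]c1=O`: -0.45

In a physicochemical assay for lipophilicity (on this read-out lower numbers stand for lower lipophilicity and higher numbers for higher lipophilicity), compound 1 stands highest of the three. The step of a number 1.83 log units lower from compound 1 to compound 2 (beyond the scatter) and the step of a number 1.47 log units lower from compound 1 to compound 3 (beyond the scatter) are both large, while a number 0.36 log units higher from compound 2 to compound 3 (beyond the scatter) is modest. Compound 4, `Cc1cn(C2CC(N=[N+]=[N-])C(COC(=O)OCCCC(=O)O)O2)c(=O)[nH]c1=O`, has not yet been measured. It differs from compound 1 by carboxy in place of methyl on a saturated chain carbon, three bonds along the chain from an oxygen next to a carbonyl group. Both measured steps away from compound 1 introduce a hydrogen-bond donor and acceptor on the ester side chain and lower this assay by a large amount, so a large drop is expected here too. The estimate for compound 4 in this assay is -0.6 (range -1.3 to 0.1), an expected step of a number 1.62 log units lower from compound 1 to compound 4 (beyond the scatter).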

Compound 4, partition coefficient: -0.55
For compound 4 the middle estimate is 0.05 log units below the measured one; measured number inside the range.
By their numbers in this assay, from the lowest: compounds 2, 4 and 3 (each within the scatter of the next, the first and the last beyond it); then compound 1.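

In this assay, carboxy in place of methyl on a saturated chain carbon, three bonds along the chain from an oxygen next to a carbonyl group, gives a large drop (a number 1.57 log units lower from compound 1 to compound 4 (beyond the scatter)). Compound 4 stays within the scatter of both chain-modified neighbours (a number 0.10 log units lower from compound 3 to compound 4 (within the scatter); a number 0.26 log units higher from compound 2 to compound 4 (within the scatter)), so here carboxy and 2-hydroxyethyl cannot be told apart, nor can 3-carboxypropoxy and (3-carboxypropyl)amino. Nothing available offers an explanation for these steps. The compounds leave open whether an amine at this position, or a longer chain ending in a carboxylic acid, would give a drop of similar size.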